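Second trifluoromethyl on the sulfone-linked ring

The source may hold more compounds than are shown below. What is called first, only, known or untested is meant among the compounds shown, and "the series" means these compounds.

All three measured compounds were tested in a functional assay on VCaP cells (Homo sapiens) for antiproliferative activity, read by propidium iodide staining, with a stated time of 96 h; on this read-out lower numbers stand for stronger inhibition and higher numbers for weaker inhibition.

Compound 1, `CC(O)(COc1ccc(C#N)cc1)C(=O)Nc1ccc(S(F)(F)(F)(F)F)cc1`: 100000 nM
Compound 2, `CC(O)(COc1ccc(C#N)cc1C(F)(F)F)C(=O)Nc1ccc(S(F)(F)(F)(F)F)cc1`: 100000 nM
Compound 3, `CC(O)(CS(=O)(=O)c1cccc(C(F)(F)F)c1)C(=O)Nc1cccc(S(F)(F)(F)(F)F)c1`: 35500 nM

From compound 1 to compound 2 the change is trifluoromethyl in place of hydrogen on an aromatic carbon, and the result is no change at the digits printed from compound 1 to compound 2 (within the scatter). Compound 3 differs from compound 1 in the core; that difference is not broken down here, and the two values show compound 3 with the lower number. Compound 4, `CC(O)(CS(=O)(=O)c1cc(C(F)(F)F)cc(C(F)(F)F)c1)C(=O)Nc1cccc(S(F)(F)(F)(F)F)c1`, has not been measured. It arises from compound 3 by trifluoromethyl in place of hydrogen on an aromatic carbon, the same kind of change as from compound 1 to compound 2, though here the entering group sits meta to a large group and meta to a trifluoromethyl group rather than ortho to a large group and meta to a cyano group. Given the flat step from compound 1 to compound 2, the expected step is a 1.2-fold lower number from compound 3 to compound 4 (0.07 log units; within the scatter). Compound 4 is therefore estimated at 30000 nM, between 10000 nM and 100000 nM.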

Compound 4, half-maximal inhibitory concentration: 10400 nM
For compound 4 the middle estimate is 2.9-fold (0.46 log units) above the measured one; the range from low to high includes it.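

In this assay, trifluoromethyl in place of hydrogen gave a 3.4-fold lower number from compound 3 to compound 4 (0.53 log units; beyond the scatter). Set beside the earlier step, the change did not carry over with the same size from one core to the other: the same change on two cores in this assay, no change at the digits printed (within the scatter) from compound 1 to compound 2 and a 3.4-fold lower number (0.53 log units; beyond the scatter) from compound 3 to compound 4, 3.4-fold (0.53 log units) apart, beyond the scatter of two such steps With only one pair on each core, this does not show which difference between the cores goes with the larger step, and the entering group also has different neighbours in the two pairs.

The compounds shown leave open whether another group in the same place on the core of compound 3, such as a chlorine atom, a methoxy group or an amine, would give a similar step. They also leave open whether a further core would follow compound 1 or compound 3.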